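The source may hold more compounds than are shown below. What is called first, only, known or untested is meant among the compounds shown, and "the series" means these compounds.

Measured so far:
compound 1 `CCCCNc1nc(N)nc2c1CCN(Cc1ccccc1)C2`, 0.4 uM
compound 2 `CCCCNc1nc(N)nc2c1CN(S(C)(=O)=O)CC2`, 9.9 uM
compound 3 `CCCCNc1nc(N)nc2c1CN(Cc1cccc(Cl)c1Cl)CC2`, 0.18 uM

In an assay on HEK293 cells for agonist activity at Toll-like receptor 8 (Homo sapiens), read by a luciferase reporter, with a stated time of 6 h (a lower number here means that less compound is needed, a higher number that more compound is needed for the effect), compound 2 stands at the highest of the three numbers: compound 1 gives 0.4 uM and compound 3 gives 0.18 uM, both beyond the scatter below compound 2. Compound 4 `CCCCNc1nc(N)nc2c1CN(C(=O)C(C)C)CC2` is not yet measured. It differs from compound 2 in one place: isopropylcarbonyl in place of methylsulfonyl on an amine nitrogen in a ring. Among the compounds with values here, no step of this kind has been measured, so the direction rests only on the spread between compound 2 and the two lower compounds. A step of the size a 2.0-fold lower number from compound 2 to compound 4 (0.30 log units; within the scatter) is expected, toward a lower number but not reaching compound 1. For compound 4 the estimate in this assay is 5 uM, with a range from 1.5 uM to 20 uM.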

Compound 4, minimum effective concentration: 1.6 uM
Estimate against measurement, compound 4: 3.1-fold (0.49 log units) above; the range from low to high includes it.
By their numbers in this assay, from the lowest: compound 3; then compound 1; then compound 4; then compound 2.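

In this assay, isopropylcarbonyl in place of methylsulfonyl on an amine nitrogen in a ring gives a 6.2-fold lower number from compound 2 to compound 4 (0.79 log units; beyond the scatter), the first single change read at this position. With the rest of compound 2 held fixed, the group on this nitrogen alone moves the number. Nothing measured on these compounds accounts for the step.

Open, as far as these compounds go, is whether a smaller acetyl, a longer chain on the carbonyl or a urea at this nitrogen would move the number the same way. Also open, from the compounds shown here alone, is whether a phenylsulfonyl would stay as high as compound 2.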